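Moving the Fluorine on the Fluorophenyl Ring

The compounds below may be only part of what the source reports. "The series", "measured", "known", "first", "only" and "open" are said of these compounds alone.

Compound 1, `CC(=O)Nc1ccc2oc(-c3cccc(F)c3)cc(=O)c2c1`, sits at a limit of an ADME assay on THP-1 cells (Homo sapiens) for cytotoxicity, read by flow cytometry and propidium iodide staining, with a stated time of 72 h (a lower number here means a stronger inhibitor, a higher number a weaker inhibitor), > 125000 nM.
Compound 2, `CC(=O)Nc1ccc2oc(-c3ccc(F)cc3)cc(=O)c2c1`, gives 22000 nM in this assay.
Compound 3, `COc1c(-c2cccc(F)c2)oc2ccc(NC(C)=O)cc2c1=O`, sits at a limit of this assay, > 125000 nM.

Compound 1 and compound 2 differ in one place: 4-fluorophenyl in place of 3-fluorophenyl on an aromatic carbon. That change brings an at least 5.6-fold lower number from compound 1 to compound 2 (0.75 log units; beyond the scatter). The size is open at one end because compound 1 is at the limit of > 125000 nM in this assay, at which 2 of the 3 values shown sit.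

Compound 3 differs from compound 1 by methoxy in place of hydrogen on an aromatic carbon. Here the step is a step that the two limits leave unreadable from compound 1 to compound 3, since both compounds sit at the limit of > 125000 nM in this assay, at which 2 of the 3 values shown sit.

Compound 4, `COc1c(-c2ccc(F)cc2)oc2ccc(NC(C)=O)cc2c1=O`, has not yet been measured in this assay. It differs from compound 3 by 4-fluorophenyl in place of 3-fluorophenyl on an aromatic carbon. Among the compounds with values here, this is the same kind of change as the one from compound 1 to compound 2, but not the same: in compound 3 the place is also ortho to a methoxy group (2 heavy atoms), which is absent in compound 1. Within the data shown here, on the one measured example, compound 4 is expected to show a step of about an at least 4.1-fold lower number from compound 3 to compound 4 (0.61 log units; beyond the scatter) from compound 3, resting on an at least 5.6-fold lower number from compound 1 to compound 2 (0.75 log units; beyond the scatter). Compound 4 is therefore estimated at about 30000 nM, with a range from 8000 nM to 125000 nM, and a real chance that this assay again reports only a limit.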

Compound 4, half-maximal inhibitory concentration: > 125000 nM
Compound 4: no number, only a limit; the forecaster's own chance of this, stated with the estimate: 35%; at least 4.1-fold (0.61 log units) between middle value and limit.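

In this assay compound 4 gives > 125000 nM, which is a limit of the assay and not a number. Neither the step from compound 3 to compound 4, which repeats the change of 3-fluorophenyl to 4-fluorophenyl on the methoxy-bearing core, nor the step from compound 1 to compound 3 can be read, since in each pair both compounds stand at the same limit: the limit of > 125000 nM in this assay, at which 3 of the 4 values shown sit. On the core of compound 1 that change gave an at least 5.6-fold lower number from compound 1 to compound 2 (0.75 log units; beyond the scatter), whereas with 4-fluorophenyl in place, methoxy in place of hydrogen gives an at least 5.6-fold higher number from compound 2 to compound 4 (0.75 log units; beyond the scatter), so the shift seen on the first core does not show up as a measurable value on the second, although this does not show that the change does nothing there, only that its size, if any, lies out of reach of the assay.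

The compounds shown leave open whether any compound on the methoxy-bearing core would give a number in this assay, as compound 2 alone does here. They also leave open how an amine, a carboxylic acid or a longer chain such as ethoxy would read at the place of the methoxy group.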